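This account rests on a few compounds, and the source may have more. Where it says the series, first, only, none or still open, it means among the compounds named here.

Measured compounds:
compound 1, `Cc1nc(N2CCC2)nc(OC2CCC2)c1O`, 100%
compound 2, `Cc1nc(OC2CCC2)nc(N2CCC2)c1O`, 101%

Both compounds were run in a functional assay on cells (Lymphocyte, Homo sapiens), read by a luciferase reporter and ATP content, with a stated time of 48 h, tested at 1 uM; on this read-out higher numbers stand for a weaker effect at the one concentration tested and lower numbers for a stronger effect. In this assay compound 1 gives 100%, and compound 2 gives 101%. Compound 2 holds the larger of the two numbers shown, but its gap to compound 1 falls within the usual scatter, so the two cannot be told apart; each reads as essentially no effect at the single concentration tested. Going by the values given here, no step between measured compounds that differ in one place is available, so there is nothing yet to show how a single change on this core moves the read-out.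

Compound 3, `Cc1nc(N2CCC2)nc(N2CCC2)c1O`, has not been measured. It differs from compound 2 in one place: azetidin-1-yl in place of cyclobutyloxy on an aromatic carbon. With compound 1 and compound 2 both sitting at no effect, nothing in the numbers points to a step in either direction beyond the scatter. Compound 3 is therefore expected to show a step of a number 2 percentage points lower from compound 2 to compound 3 (within the scatter), which amounts to none beyond the scatter. Compound 3 is estimated to give 99%, with a likely range from 84% to 112%.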

Compound 3, a percentage reported as activity, at one concentration (the size of the read-out at that concentration, not a potency): 101%
Estimate against measurement, compound 3: 2 percentage points below, within the range that was stated.
By their numbers in this assay, from the lowest: compounds 1, 2 and 3 (each within the scatter of the next).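

In this assay, going by these compounds alone, putting azetidin-1-yl in place of cyclobutyloxy on the aromatic carbon between two ring nitrogen atoms gives no change at the digits printed from compound 2 to compound 3 (within the scatter) and is the first single change on this core that can be read. The same exchange, made at the place where compound 1 carries its cyclobutyloxy, gives a number 1 percentage points higher from compound 1 to compound 3 (within the scatter) as its result, so neither place shows a step beyond the usual scatter, and the exchange of oxygen-linked cyclobutyl for azetidine brings out no effect at the one concentration tested. Nothing available here offers an explanation for this flat result.

On these data alone, since all three compounds sit at essentially no effect, it stays open whether any group at these two places can move the read-out at all, for instance a carboxylic acid or a longer chain such as butoxy. Also open, as far as these compounds go, is what happens on the rest of the core, such as when an amine takes the place of the hydroxy group, and how these compounds behave at other concentrations.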